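N-methylation of amides and buffer solubility in the series

The compounds below may be only part of what the source reports. "The series", "measured", "known", "first", "only" and "open" are said of these compounds alone.

Measured so far:
compound 1 `CN(C(=O)c1ccccc1)c1cnc(NCc2c(F)ccc3c2CCO3)n2cnnc12`: 280000 nM
compound 2 `O=C(Nc1cnc(NCc2c(F)ccc3c2CCO3)n2cnnc12)c1ccccc1`: 2000 nM
compound 3 `CNC(=O)c1ccc(-c2cnc(NCc3c(F)ccc4c3CCO4)c3cn[nH]c(=O)c23)c(C)n1`: 19000 nM

In a physicochemical assay for solubility, read by LC-MS, in phosphate buffer, with a stated time of 24 h, at pH 7.4 (on this read-out higher numbers stand for higher solubility and lower numbers for lower solubility), compound 1 gives 280000 nM, compound 2 gives 2000 nM and compound 3 gives 19000 nM. The change methyl in place of hydrogen on an amide-type nitrogen made the step of a 140-fold higher number from compound 2 to compound 1 (2.15 log units; beyond the scatter). The difference between the core of compound 2 and the core of compound 3 is not broken down here.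

Compound 4 `Cc1nc(C(=O)N(C)C)ccc1-c1cnc(NCc2c(F)ccc3c2CCO3)c2cn[nH]c(=O)c12` is not yet measured. It differs from compound 3 by methyl in place of hydrogen on an amide-type nitrogen, the same kind of change as from compound 2 to compound 1, although the amide-type nitrogen there carries an aromatic carbon and a carbonyl carbon, whereas in compound 3 it carries a carbonyl carbon and a saturated chain carbon. Because the earlier step of a 140-fold higher number from compound 2 to compound 1 (2.15 log units; beyond the scatter) was large, a rise is expected for compound 4, though a smaller one is estimated, a 10-fold higher number from compound 3 to compound 4 (1.00 log units; beyond the scatter), since the cores differ. Compound 4 is estimated at 190000 nM, likely between 40000 nM and 600000 nM.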

Compound 4, solubility: 403000 nM
Estimate against measurement, compound 4: 2.1-fold (0.33 log units) below, and the stated range covers the measured number.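

In this assay methyl in place of hydrogen on an amide-type nitrogen gives a 21-fold higher number from compound 3 to compound 4 (1.33 log units; beyond the scatter) and so matches in direction a 140-fold higher number from compound 2 to compound 1 (2.15 log units; beyond the scatter) on a second core, with neither pair going against the other. Two pairs set no rule for other cores, and the nitrogen also differs: its other neighbours are a carbonyl carbon and a saturated chain carbon in compound 3, but an aromatic carbon and a carbonyl carbon in compound 2. Nothing shown bears on what lies behind either rise.

Still open, as far as these compounds go, is whether ethyl, a longer chain on the same amide-type nitrogen, would go the same way as methyl. Also open, from the compounds shown here alone, is how a carboxylic acid or an amine in place of dimethylcarbamoyl would read.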